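The source may report more compounds than this note shows. Statements on the series, on what has been measured and on what is new or still open speak of the compounds shown alone.

Notes on the series. Among the measured compounds shown here, compound 1 `COc1cc(Cl)cc(-c2nn(-c3cccc(NC(=O)c4ccc(Cl)c(Cl)c4)c3)cc2-c2ccncc2)c1` is the reference point; in a functional assay on MOLT-4 cells (Homo sapiens) for inhibition, read by sulforhodamine B assay, with a stated time of 48 h, tested at 10 uM (on this read-out higher numbers stand for a weaker effect at the one concentration tested and lower numbers for a stronger effect), compound 1 gives 54.9%, the highest of the three numbers measured so far and hence the weakest effect at the one concentration tested. Compounds 2 and 3 sit far lower: compound 2 `COc1cc(Cl)cc(-c2nn(-c3cccc(NC(=O)Nc4ccc(Cl)c(C(F)(F)F)c4)c3)cc2-c2ccncc2)c1` gives -9.68% and compound 3 `COc1cc(Cl)cc(-c2nn(-c3cccc(NC(=O)Nc4cc(C(F)(F)F)cc(C(F)(F)F)c4)c3)cc2-c2ccncc2)c1` gives -24.7%. For the measured compounds named here, the only tabulated step from compound 1, a number 64.6 percentage points lower from compound 1 to compound 2 (beyond the scatter), puts (4-chloro-3-(trifluoromethyl)phenyl)amino in place of 3,4-dichlorophenyl on the carbonyl carbon, so it alters both the link to the carbonyl and the aryl group at once and does not separate the two.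

Compound 4 `COc1cc(Cl)cc(-c2nn(-c3cccc(NC(=O)c4cccc(C(F)(F)F)c4)c3)cc2-c2ccncc2)c1` differs from compound 1 by 3-(trifluoromethyl)phenyl in place of 3,4-dichlorophenyl on a carbonyl carbon. Going by the values given here, no measured pair isolates an exchange of the aryl group on the carbonyl carbon alone, so the large step from compound 1 to compound 2 cannot be carried over to compound 4 as it stands. With the attachment to the carbonyl kept as in compound 1, the expected step in this assay is a number 4.9 percentage points lower from compound 1 to compound 4 (within the scatter), within the scatter or close to it, with no firm direction. Compound 4 is therefore estimated at 50%, with a range from 20% to 80%.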

Compound 4, a percentage reported as activity, at one concentration (the size of the read-out at that concentration, not a potency): 29%
Estimate against measurement, compound 4: 21 percentage points above; the range from low to high includes it.
By their numbers in this assay, from the lowest: compound 3; then compound 2; then compound 4; then compound 1.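

With the attachment to the carbonyl kept as in compound 1, the aryl group alone is enough to shift the read-out in this assay, as 3-(trifluoromethyl)phenyl in place of 3,4-dichlorophenyl on a carbonyl carbon whose other neighbour is an amide-type nitrogen gives a modest step (a number 25.9 percentage points lower from compound 1 to compound 4 (beyond the scatter)). This exchange does not close the distance to the amino-linked group of compound 2, and the step back from that group to 3-(trifluoromethyl)phenyl is large (a number 38.7 percentage points higher from compound 2 to compound 4 (beyond the scatter)), so the two ways of changing this position now stand apart on the read-out. No measurement on hand accounts for either step.

The compounds shown leave open how the remaining distance divides between the amino link on the carbonyl and the substituents on the aryl ring, as no pair here holds one aryl group constant while only that link changes. Going by these compounds, a (3-(trifluoromethyl)phenyl)amino group or a 4-chloro-3-(trifluoromethyl)phenyl group on the carbonyl carbon would each separate the two, and whether a nitrile on the ring can stand in for trifluoromethyl also remains open.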